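Benzyl in Place of Cyclohexyl: An Expected Partial Recovery

This account rests on a few compounds, and the source may have more. Where it says the series, first, only, none or still open, it means among the compounds named here.

Measured so far:
compound 1 `Nc1ccccc1NC(=O)/C=C/c1ccc(Cn2cnc3c(Nc4cccc(OC(F)(F)F)c4)nc(Cl)nc32)cc1`: 66.7%
compound 2 `Nc1ccccc1NC(=O)/C=C/c1ccc(Cn2cnc3c(NC4CCCCC4)nc(Cl)nc32)cc1`: 24.9%

In a functional assay on NCI-H460 cells (Homo sapiens) for antiproliferative activity, read by CCK-8 assay, with a stated time of 72 h, tested at 8 uM (a lower number here means a weaker effect, a higher number a stronger effect of the compound at the concentration tested), compound 1 gives 66.7%, while compound 2 gives 24.9%, the lowest of the two numbers. Compound 3 `Nc1ccccc1NC(=O)/C=C/c1ccc(Cn2cnc3c(NCc4ccccc4)nc(Cl)nc32)cc1` differs from compound 2 by benzyl in place of cyclohexyl on a nitrogen on an aromatic ring. For the measured compounds named here, the only measured step, a number 41.8 percentage points lower from compound 1 to compound 2 (beyond the scatter), bears on this: exchanging an aromatic group for cyclohexyl on that nitrogen cut the inhibition sharply. Benzyl brings back an aromatic ring, though with one more carbon between ring and nitrogen. A rise beyond the scatter, yet smaller than the drop seen, is therefore expected, estimated as a number 20.1 percentage points higher from compound 2 to compound 3 (beyond the scatter). The expected value for compound 3 is 45%, within 25% to 65%.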

Compound 3, a percentage reported as inhibition, at one concentration (the size of the read-out at that concentration, not a potency): 49.1%
For compound 3 the middle estimate is 4.1 percentage points below the measured one, and the stated range covers the measured number.
By their numbers in this assay, from the lowest: compound 2; then compound 3; then compound 1.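

In this assay the step of a number 24.2 percentage points higher from compound 2 to compound 3 (beyond the scatter) shows that benzyl restores much of the inhibition lost with cyclohexyl, so a saturated ring is not the only option on this nitrogen. The step of a number 17.6 percentage points lower from compound 1 to compound 3 (beyond the scatter) shows that this recovery is partial, and benzyl does not match 3-(trifluoromethoxy)phenyl. No available measurement explains either difference. Because benzyl and 3-(trifluoromethoxy)phenyl differ in more than one feature, the compounds shown cannot tell which feature matters. Plain phenyl, 4-methoxybenzyl and the longer phenethyl chain remain open comparisons at this position.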